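Swapping an Ester for an Ethyl Group on a Urea

The source may hold more compounds than are shown below. What is called first, only, known or untested is meant among the compounds shown, and "the series" means these compounds.

Compound 1 `COC(=O)c1ccc(NC(=O)Nc2cc(C)nc3ccccc23)cc1` is a urea that links two aromatic parts, and its outer ring carries a methoxycarbonyl group. In an ADME assay on Raji cells (Homo sapiens) for cytotoxicity, with a stated time of 72 h (on this read-out higher numbers stand for an effect only at larger amounts of compound and lower numbers for an effect already at smaller amounts), compound 1 gives 17000 nM, the only actual number among the three results shown. Compound 2 `Cc1cc(NC(=O)Nc2cccc([N+](=O)[O-])c2)c2ccccc2n1` differs from compound 1 in the groups on that outer ring. In this assay compound 2 reaches only a limit of the measurement, > 25000 nM. Compound 3 `COc1ccc(NC(=O)Nc2cc(C)nc3ccccc23)cc1OC` also differs from compound 1 in the groups on that outer ring. For compound 3 this assay likewise reports only a limit, > 25000 nM. Thus the limit of > 25000 nM in this assay, at which 2 of the 3 values shown sit, marks where most of the measured compounds sit, and compound 1 alone falls inside the window where a number can be read.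

Compound 4 `CCc1ccc(NC(=O)Nc2cc(C)nc3ccccc23)cc1` has not yet been measured in this assay. It differs from compound 1 in one place: ethyl in place of methoxycarbonyl on an aromatic carbon. Going by the values given here, no pair of measured compounds differs in a single place, so no measured step shows what such a change does here. The step of a 1.1-fold lower number from compound 1 to compound 4 (0.05 log units; within the scatter) is expected to stay within the usual scatter. Compound 4 is therefore estimated at 15000 nM, with a range from 6000 nM to 25000 nM.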

Compound 4, half-maximal effective concentration: > 25000 nM
Compound 4: a limit, no number; the forecaster's own chance of this, stated with the estimate: 35%; at least 1.6-fold (0.22 log units) between middle value and limit.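

Going by these compounds alone, this is the first comparison in the set where only one place changes: on an aromatic carbon, para to a large group, ethyl takes the place of methoxycarbonyl. In this assay this swap gives an at least 1.4-fold higher number from compound 1 to compound 4 (0.16 log units; that floor lies within the scatter); compound 4 reaches only a limit of the measurement, so this figure is a floor and not a measured size, and it does not by itself establish a real change. What the pair does show is that ethyl at this position gives no readable number, leaving compound 1 alone inside the measurable window while the other compounds gather at one point: the limit of > 25000 nM in this assay, at which 3 of the 4 values shown sit.

From the compounds shown here alone, how far compound 4 lies beyond that limit stays open, and so does the true size of the step from the ester to ethyl. Also open, going by these compounds, is whether the readable number of compound 1 is tied to its methoxycarbonyl group in particular, a question that a carboxylic acid, an amide or an amine at this same place on the outer ring, or a longer chain in place of ethyl, could help to settle.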